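Removing the Trifluoromethyl Group: From Compound 3 to Compound 4

A few compounds are considered here, and "the series" means these few. Any claim that something is new, unique, unknown or untested is made for them only; others in the source may bear on it.

Of the compounds shown here, three built on one shared core have been tested in a functional assay on Huh-7 cells (Homo sapiens) for inhibition, read by sulforhodamine B assay, with a stated time of 72 h; on this read-out higher numbers stand for weaker inhibition and lower numbers for stronger inhibition. Compound 1 `COc1ccc2cc(C(C)c3nnc4n3N=C(c3ccc(C)cc3)CS4)ccc2c1` gives 8200 nM. Compound 2 `CC(C)Cc1ccc(C(C)c2nnc3n2N=C(c2ccc(Br)cc2)CS3)cc1`, which carries a bromo group on its outer aromatic ring, gives 4900 nM in this assay. Compound 3 `CC(C)Cc1ccc(C(C)c2nnc3n2N=C(c2ccc(C(F)(F)F)cc2)CS3)cc1`, with trifluoromethyl in place of bromo on an aromatic carbon, gives 8400 nM. That exchange produced a 1.7-fold higher number from compound 2 to compound 3 (0.23 log units; within the scatter). Compound 3 thus holds the highest of the three numbers, but both neighbours sit within the scatter of it: compound 1 is a near match, and compound 2 differs only by the step just described.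

Compound 4 `CC(C)Cc1ccc(C(C)c2nnc3n2N=C(c2ccccc2)CS3)cc1` differs from compound 3 in one place: hydrogen in place of trifluoromethyl on an aromatic carbon. Among the compounds with values here, the only measured step at this position, a 1.7-fold higher number from compound 2 to compound 3 (0.23 log units; within the scatter), shows that swapping one group for another there moved the number no further than repeated measurements would. Nothing measured tells what happens when the position carries only hydrogen, so the step of a 1.2-fold lower number from compound 3 to compound 4 (0.08 log units; within the scatter) is expected to remain within the scatter as well. Compound 4 is therefore estimated to give about 7000 nM in this assay, with a range from 3000 nM to 18000 nM.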

Compound 4, half-maximal inhibitory concentration: 6100 nM
Compound 4: the middle estimate sits 1.1-fold (0.06 log units) above what was measured, and the stated range covers the measured number.
By their numbers in this assay, from the lowest: compounds 2, 4, 1 and 3 (each within the scatter of the next).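

On this aromatic carbon, para to a large group, the outer ring can go from 4-(trifluoromethyl)phenyl to plain phenyl in this assay and the result (a 1.4-fold lower number from compound 3 to compound 4 (0.14 log units; within the scatter)) stays within the scatter. Hydrogen also matches bromo at this place (a 1.2-fold higher number from compound 2 to compound 4 (0.10 log units; within the scatter)), so bromo, trifluoromethyl and hydrogen, carried by compounds that are otherwise identical, cannot be told apart here, and among these three compounds the number does not depend on having a substituent at this place at all. Nothing available explains this result in terms of the groups themselves.

Going by these compounds, whether a quite different group on this carbon, such as an amine, a carboxylic acid or a longer chain, would give a number beyond the scatter remains open, since every group seen so far gives a comparable result. Also open, on these data alone, is how much the rest of the molecule contributes to the activity, since compound 1 differs from the others in more than one place and cannot be compared with them directly.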